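Moving a Ring Hydroxyl Across Two Related Cores

The source may report more compounds than this note shows. Statements on the series, on what has been measured and on what is new or still open speak of the compounds shown alone.

Compound 1 `O=C(/C=C/c1cccc(O)c1)CC(=O)/C=C/c1cccc(O)c1O` and compound 2 `O=C(/C=C/c1ccc(O)cc1)CC(=O)/C=C/c1cccc(O)c1O` share one core, while compound 3 `O=C(/C=C/c1cccc(O)c1)/C=C/c1ccc(O)c(O)c1` and compound 4 `O=C(/C=C/c1ccc(O)cc1)/C=C/c1ccc(O)c(O)c1` share another; the difference between the two cores is not broken down here. In a physicochemical assay for solubility, using the shake flask method, with a stated time of 12 h (a higher number here means a more soluble compound, a lower number a less soluble compound), compound 1 gives 8200 nM and compound 2 gives 4800 nM. The change between them is 4-hydroxyphenyl in place of 3-hydroxyphenyl on a double-bonded chain carbon bound to a double-bonded chain carbon, and it made the step of a 1.7-fold lower number from compound 1 to compound 2 (0.23 log units; within the scatter). In this assay compound 3 gives 60000 nM, the highest of the three measured numbers. Among the compounds with values here, compound 4 carries the same change, (4-hydroxyphenyl in place of 3-hydroxyphenyl on a double-bonded chain carbon bound to a double-bonded chain carbon), so the earlier step is the only guide to what it will do. Because the step of a 1.7-fold lower number from compound 1 to compound 2 (0.23 log units; within the scatter) was small, the estimated step for compound 4 is a 1.5-fold lower number from compound 3 to compound 4 (0.18 log units; within the scatter) in this assay. Within the data shown here, the expected value for compound 4 in this assay is therefore 40000 nM, with a likely range from 15000 nM to 100000 nM; only one earlier step supports this, so the range is kept wide.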

Compound 4, solubility: 19000 nM
The estimate for compound 4 lay 2.1-fold (0.32 log units) above the measured number, and the stated range covers the measured number.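

In this assay, 4-hydroxyphenyl in place of 3-hydroxyphenyl gives a 3.2-fold lower number from compound 3 to compound 4 (0.50 log units; beyond the scatter) on the second core, while the same change gives a 1.7-fold lower number from compound 1 to compound 2 (0.23 log units; within the scatter) on the first. The change therefore stands clear of the scatter on the core of compound 3 but not on the core of compound 1, and the small step on one core did not settle how large the step would be on the other. With only these two pairs, this does not show that the change has a fixed size or a general direction in the series, and nothing shown here accounts for the result.

The compounds shown leave open whether a third core would follow either step, and whether the result is tied to the hydroxyl group. As far as these compounds go, how an amine or a carboxylic acid in that ring position would behave in this assay also remains open.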